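The source may report more compounds than this note shows. Statements on the series, on what has been measured and on what is new or still open speak of the compounds shown alone.

Measured so far:
compound 1 `CCOC(=O)N(C)C(C)C#CCn1ccnc1` — 54 mg/kg
compound 2 `CCOC(=O)N(C)C(C)C#CCn1cncc1C` — 9.7 mg/kg
compound 3 `O=C1NCCN1CC#CCn1ccnc1` — > 100 mg/kg

In a functional assay on the whole organism for antagonist activity, with Mus musculus as the target (on this read-out higher numbers stand for an effect only at larger amounts of compound and lower numbers for an effect already at smaller amounts), compound 1 gives 54 mg/kg. Compound 2 carries methyl in place of hydrogen on an aromatic carbon; the step of a 5.6-fold lower number from compound 1 to compound 2 (0.75 log units; beyond the scatter). Compound 3 gives no number but only a limit of this assay, > 100 mg/kg; this is the limit of > 100 mg/kg in this assay, at which 1 of the 3 values shown sits. The difference between the core of compound 3 and the core of compound 1 is not broken down here.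

Compound 4 `Cc1cncn1CC#CCN1CCNC1=O` is not yet measured. It differs from compound 3 by methyl in place of hydrogen on an aromatic carbon, the same change as from compound 1 to compound 2. For compound 4 the step of an at least 1.6-fold lower number from compound 3 to compound 4 (0.22 log units; that floor lies within the scatter) is expected, resting on a 5.6-fold lower number from compound 1 to compound 2 (0.75 log units; beyond the scatter); since compound 3 sits at a limit, compound 4 may still end at a limit. Compound 4 is estimated at 60 mg/kg, between 20 mg/kg and 200 mg/kg.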

Compound 4, dose for half-maximal effect: 21 mg/kg
Compound 4: middle estimate off by 2.9-fold (0.46 log units), on the high side, and the stated range covers the measured number.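

In this assay, methyl in place of hydrogen on an aromatic carbon gives an at least 4.7-fold lower number from compound 3 to compound 4 (0.67 log units; beyond the scatter), the same direction as on the core of compound 1. Compound 3 stands at a limit of the assay, > 100 mg/kg, so the size of the step on this core stays unfixed and only its floor is known. The change carries over in direction on these two cores, but equal size is not shown, and two cores make no rule for others: the same change on two cores in this assay, a 5.6-fold lower number (0.75 log units; beyond the scatter) from compound 1 to compound 2 and an at least 4.7-fold lower number (0.67 log units; beyond the scatter) from compound 3 to compound 4; the limit leaves it open whether they differ.

Open, from the compounds shown here alone, is whether ethyl or chlorine in place of the methyl would act alike on either core. Also open, going by these compounds, is how the step behaves on a core carrying an amine or a longer chain.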